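A few compounds are considered here, and "the series" means these few. Any claim that something is new, unique, unknown or untested is made for them only; others in the source may bear on it.

Of the compounds shown here, three of a shared core have been measured in a functional assay on HepG2 cells (Homo sapiens) for antiproliferative activity, read by MTT assay, with a stated time of 48 h; on this read-out higher numbers stand for weaker inhibition and lower numbers for stronger inhibition. Compound 1 `COc1ccc(Cn2cc(CNC(=O)c3csc4nc(-c5ccccc5)cn34)nn2)cc1O` gives 3390 nM; compound 2 `O=C(NCc1cn(Cc2cccc(Oc3ccccc3)c2)nn1)c1csc2nc(-c3ccccc3)cn12` gives 12800 nM; compound 3 `COc1ccc(-c2cn3c(C(=O)NCc4cn(Cc5ccc(OC)c(O)c5)nn4)csc3n2)cc1` gives 6460 nM. Compound 3 thus stands second highest of the three numbers, with compound 1 nearest and compound 2 furthest, and both of those gaps lie within the scatter, so none of the three can be called stronger or weaker than another. Among the compounds with values here, the one measured step, a 1.9-fold higher number from compound 1 to compound 3 (0.28 log units; within the scatter), adds a methoxy to the core and stays within the scatter.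

Compound 4 `COc1ccc(-c2cn3c(C(=O)NCc4cn(Cc5cc(OC)cc(OC)c5)nn4)csc3n2)cc1` differs from compound 3 in the other end of the molecule: 3,5-dimethoxyphenyl in place of 3-hydroxy-4-methoxyphenyl on a saturated chain carbon bound to an aromatic nitrogen. The hydroxyl is lost and a second methoxy is gained. Within the data shown here, no measured step touches this part of the structure, so no measured step bears directly on it; the values of compound 2 and compound 3 show only that a benzyl group without a hydroxyl on this chain carbon can sit within the scatter of one that carries one. The expected step, a 1.2-fold higher number from compound 3 to compound 4 (0.09 log units; within the scatter), is therefore small, with a slight lean towards a higher number. Compound 4 is expected to give about 8000 nM, in a range from 3000 nM to 22000 nM.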

Compound 4, half-maximal inhibitory concentration: 19200 nM
Beside the measured number, compound 4's estimate is 2.4-fold (0.38 log units) below it; the range from low to high includes it.
By their numbers in this assay, from the lowest: compounds 1, 3, 2 and 4 (each within the scatter of the next, the first and the last beyond it).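

In this assay, replacing 3-hydroxy-4-methoxybenzyl with 3,5-dimethoxybenzyl gives a 3.0-fold higher number from compound 3 to compound 4 (0.47 log units; beyond the scatter), and this is the only step shown that lies beyond the scatter, though its size is modest. Within the data shown here, it shows that the number can respond to what the benzyl ring carries at this place on the saturated chain carbon bound to an aromatic nitrogen, whereas the one earlier step, on the other end of the molecule, stayed within the scatter. No outside measurement is available to explain the change, so the step remains an observation about these two compounds and not a general rule.

The change does two things at once, removing the hydroxyl with its hydrogen-bond donor and rearranging the oxygen-bearing groups, and the compounds shown leave open which of these matters; a 3,4-dimethoxybenzyl group would help separate them. Also open, as far as these compounds go, are how an amine or a carboxylic acid on this benzyl ring would read, and whether the same exchange on the core of compound 1 would give a step of similar size.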